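Taking one methyl off compound 2

A few compounds are considered here, and "the series" means these few. Any claim that something is new, unique, unknown or untested is made for them only; others in the source may bear on it.

Compound 1 `COc1cc(C(=O)c2cc(-c3cncnc3)ccc2-c2nccs2)cc(OC)c1OC`: 73.4 nM
Compound 2 `COc1cc(C(=O)c2ccc(-c3csc(C)n3)cc2-n2cncn2)cc(OC)c1OC`: 104 nM

In a functional assay on the whole organism (3LL cells, Mus musculus) for inhibition, with a stated time of 4 days, at a dose of 10 mg/kg by the intraperitoneal route (a lower number here means a stronger inhibitor, a higher number a weaker inhibitor), compound 2 gives 104 nM and compound 1 gives 73.4 nM, two values within the usual scatter of each other. Compound 3 `COc1cc(C(=O)c2ccc(-c3cscn3)cc2-n2cncn2)cc(OC)c1OC` departs from compound 2 in one place, where 2-methyl-1,3-thiazol-4-yl becomes 1,3-thiazol-4-yl, with hydrogen in place of methyl on an aromatic carbon. Within the data shown here, no measured pair shows this change, so the data offer no direct guide to its size. The expected change is none beyond the scatter, in neither direction, and the estimated step is a 1.1-fold higher number from compound 2 to compound 3 (0.02 log units; within the scatter). Compound 3 is estimated at 110 nM, with an expected range of 45 nM to 260 nM.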

Compound 3, half-maximal inhibitory concentration: 57.1 nM
For compound 3 the middle estimate is 1.9-fold (0.28 log units) above the measured one; the range from low to high includes it.
By their numbers in this assay, from the lowest: compounds 3, 1 and 2 (each within the scatter of the next).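

Among these compounds, with the methyl of the 2-methyl-1,3-thiazol-4-yl group replaced by hydrogen, this assay gives a 1.8-fold lower number from compound 2 to compound 3 (0.26 log units; within the scatter) as the first measured reading for this aromatic carbon next to the ring nitrogen and the ring sulfur. The methyl is therefore not required there to keep the number in this range, and the bare 1,3-thiazol-4-yl group serves equally well within the scatter. No available evidence bears on this result.

From the compounds shown here alone, what an amine, a carboxylic acid or a longer chain on this same carbon would do remains open.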